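Methoxy in Place of Phenylsulfanyl: Expected Cytotoxicity

The source may report more compounds than this note shows. Statements on the series, on what has been measured and on what is new or still open speak of the compounds shown alone.

Measured so far:
Compound 1, `CCCCSC1=CC(=O)C(C[C@]2(C)[C@@H](C)CC[C@]3(C)C(C)=CCC[C@@H]23)=CC1=O`: 12500 nM
Compound 2, `CC1=CCC[C@H]2[C@](C)(CC3=CC(=O)C=C(Sc4ccccc4)C3=O)[C@@H](C)CC[C@]12C`: 17400 nM

Of the compounds shown here, two on a shared core have been measured. In a functional assay on K562 cells (Homo sapiens) for cytotoxicity, read by MTT assay (on this read-out lower numbers stand for stronger inhibition and higher numbers for weaker inhibition), compound 1 gives 12500 nM, and compound 2 gives 17400 nM. Compound 2 shows the higher of the two numbers, yet the gap to compound 1 lies within the usual scatter of repeated measurements, so the two stand side by side rather than apart, and neither can be called the stronger one.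

Compound 3, `COC1=CC(=O)C=C(C[C@]2(C)[C@@H](C)CC[C@]3(C)C(C)=CCC[C@@H]23)C1=O`, has not yet been measured in this assay. Its difference from compound 2 is counted as methoxy in place of phenylsulfanyl on a double-bonded ring carbon. Among the measured compounds shown here, no measured pair among the compounds at hand carries a change of this kind, so there is nothing to size the step from directly; the only guide is that compound 1 and compound 2 hold the same level. On that basis the step of a 1.1-fold lower number from compound 2 to compound 3 (0.04 log units; within the scatter) is expected to be none beyond the scatter, with wide uncertainty in either direction. Compound 3 is estimated to give 16000 nM in this assay, within a range from 5000 nM to 50000 nM.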

Compound 3, half-maximal inhibitory concentration: 2100 nM
For compound 3 the middle estimate is 7.6-fold (0.88 log units) above the measured one; the measured number lies below the stated range.
By their numbers in this assay, from the lowest: compound 3; then compounds 1 and 2 (each within the scatter of the next).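

In this assay the double-bonded ring carbon, two ring bonds from the ring atom that bears a large group, proves sensitive to what it carries: methoxy in place of phenylsulfanyl gives an 8.3-fold lower number from compound 2 to compound 3 (0.92 log units; beyond the scatter) and so moves the number beyond the scatter. Among the compounds shown here, the earlier values could not show this, as compound 1 and compound 2 stood within the scatter of each other and offered no step at this place. Nothing at hand accounts for the size of the step, though the change removes an aromatic ring and swaps sulfur for oxygen as the atom on the ring carbon.

This single step cannot tell whether the lower number follows from the loss of the aromatic ring, from the change of linking atom, or from the smaller count of heavy atoms. It also leaves open how the same carbon would respond to other groups, such as ethoxy, a hydroxyl or an amine, and whether any of them would go further than methoxy or fall back towards phenylsulfanyl.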